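Oxindole series: swapping an ester for a trifluoromethylphenyl group

This account rests on a few compounds, and the source may have more. Where it says the series, first, only, none or still open, it means among the compounds named here.

Measured compounds:
- compound 1, `COc1ccc(-c2ccc3c(c2)C(=O)C(=O)N3Cc2ccc(F)cc2)cc1`, 560 nM
- compound 2, `COC(=O)/C=C1\C(=O)N(Cc2ccc(OC)cc2)c2ccc(-c3ccc(OC)cc3)cc21`, 1900 nM

Of the compounds shown here, two have been tested so far in a functional assay on K562 cells (Homo sapiens) for antiproliferative activity, read by MTT assay, with a stated time of 48 h; on this read-out higher numbers stand for weaker inhibition and lower numbers for stronger inhibition. Compound 1 gives 560 nM, and compound 2 gives 1900 nM. Of these two numbers, compound 2 carries the higher one, which on this read-out means weaker inhibition of the cells; the gap between compound 2 and compound 1 is beyond the usual scatter of repeated measurements, so the difference is real rather than noise. The two compounds differ in more than one place, so nothing can be said about which part of their structures accounts for that gap.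

The next compound, compound 3, `COc1ccc(CN2C(=O)/C(=C\c3ccc(C(F)(F)F)cc3)c3cc(-c4ccc(OC)cc4)ccc32)cc1`, keeps the shared core of compound 2 and changes a single piece: 4-(trifluoromethyl)phenyl in place of methoxycarbonyl on a double-bonded chain carbon bound to a double-bonded ring carbon. Within the data shown here, no step between measured compounds mirrors this change, so any expectation rests on compound 2 alone. A modest move toward stronger inhibition in this assay is expected, though a step of no real size beyond the scatter would not be surprising. Compound 3 is therefore estimated at 1000 nM, within a range from 300 nM to 4000 nM, which corresponds to an expected step of a 1.9-fold lower number from compound 2 to compound 3 (0.28 log units; within the scatter).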

Compound 3, half-maximal inhibitory concentration: 1900 nM
The estimate for compound 3 lay 1.9-fold (0.28 log units) below the measured number; the measured number falls inside the stated range.
By their numbers in this assay, from the lowest: compound 1; then compounds 2 and 3 (each within the scatter of the next).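

In this assay, placing 4-(trifluoromethyl)phenyl where methoxycarbonyl stood, on a double-bonded chain carbon bound to a double-bonded ring carbon, brings no change at the digits printed from compound 2 to compound 3 (within the scatter). Among these compounds, this is the first comparison that changes only one place, and it shows that a group of 10 heavy atoms containing a six-membered aromatic ring can stand here in place of a group of 4 heavy atoms with no ring, without moving the number beyond the scatter, even though the 2 hydrogen-bond acceptors of methoxycarbonyl leave with it. Nothing measured on these compounds speaks to what lies behind this result.

From the compounds shown here alone, both groups seen at this position have no net charge and no hydrogen-bond donors, so what a carboxylic acid or an amine would do here remains open. Also open is which structural difference from compound 2 accounts for the value of compound 1, 560 nM, since those two compounds differ in more than one place.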